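Carbamate variation in a bis(trimethoxybenzoyl)piperazine series

This account rests on a few compounds, and the source may have more. Where it says the series, first, only, none or still open, it means among the compounds named here.

The series rests on a shared core carrying two trimethoxybenzoyl groups, with a side chain that differs between members. Compound 1 `COc1cc(C(=O)N2CCN(C(=O)c3cc(OC)c(OC)c(OC)c3)C(COC(=O)C(C)(C)C)C2)cc(OC)c1OC` bears a pivalate ester on that chain, and in a functional assay (Oryctolagus cuniculus) for inhibition of platelet-activating factor receptor (Cavia porcellus) (on this read-out higher numbers stand for weaker inhibition and lower numbers for stronger inhibition), compound 1 gives 100 nM; 100 nM; 120 nM (3 entries) across repeated runs (the several entries of compound 1 in this assay, 100 nM; 100 nM; 120 nM (3 entries)). Among the measured compounds shown here, compound 2 `COc1cc(C(=O)N2CCN(C(=O)c3cc(OC)c(OC)c(OC)c3)C(COC(=O)NC(C)C(C)C)C2)cc(OC)c1OC` carries a carbamate instead, and in this assay compound 2 gives 80 nM; that is the only single number for compound 2, a further entry giving no single number, and it sits within the usual scatter of the value of compound 1. Compound 3 `CCCCCN(CCCCC)C(=O)OCC1CN(C(=O)c2cc(OC)c(OC)c(OC)c2)CCN1C(=O)c1cc(OC)c(OC)c(OC)c1` changes the carbamate nitrogen substituent: dipentylamino in place of (1,2-dimethylpropyl)amino on a carbonyl carbon. For the measured compounds named here, no measured pair shows what such a change does here, so the expected step from compound 2 to compound 3 is modest, a 1.9-fold higher number from compound 2 to compound 3 (0.27 log units; within the scatter), with no clear direction beyond the scatter. Compound 3 is therefore expected to give about 150 nM, within 50 nM to 500 nM.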

Compound 3, half-maximal inhibitory concentration: 11400 nM
Compound 3: the middle estimate sits 76-fold (1.88 log units) below what was measured, outside the stated range (above it).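

With dipentylamino in place of (1,2-dimethylpropyl)amino on a carbonyl carbon, this assay records a 140-fold higher number from compound 2 to compound 3 (2.15 log units; beyond the scatter). The earlier compounds shown here, a pivalate ester and a carbamate with values within the usual scatter of each other, had given no sign that this side chain could matter so much, whereas this result shows that the substituent on the carbamate nitrogen strongly affects the read-out. The step also far exceeds the spread among repeated runs of a single compound: the several entries of compound 1 in this assay, 100 nM; 100 nM; 120 nM (3 entries).

Dipentylamino differs from (1,2-dimethylpropyl)amino both in having no hydrogen-bond donor and in its larger heavy-atom count, and compound 2 and compound 3 alone cannot separate these two differences. From the compounds shown here alone, a carbamate bearing pentylamino, which keeps the nitrogen hydrogen, or dimethylamino, which loses it on a short group, remains open.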